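A few compounds are considered here, and "the series" means these few. Any claim that something is new, unique, unknown or untested is made for them only; others in the source may bear on it.

Three compounds have been measured in an ADME assay on A549 cells (Homo sapiens) for cytotoxicity, read by MTT assay, with a stated time of 48 h; on this read-out lower numbers stand for stronger inhibition of growth and higher numbers for weaker inhibition of growth:

Compound 1 `O=C(/C=C\c1ccccc1)N1N=C(c2ccncc2)OC1c1c[nH]c2ccccc12` gives > 30 ug/mL, which is a limit of the assay.
Compound 2 `O=C(/C=C\c1ccccc1O)N1N=C(c2ccncc2)OC1c1c[nH]c2ccccc12` gives > 30 ug/mL, again a limit.
Compound 3 `O=C(/C=C\c1cccc(Cl)c1)N1N=C(c2ccncc2)OC1c1c[nH]c2ccccc12` gives > 30 ug/mL, also a limit.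

Within the data shown here, compound 2 thus stands at the upper limit of the read-out, as the limit of > 30 ug/mL in this assay, at which 3 of the 3 values shown sit, shows for every value so far. The steps from compound 1 to compound 2 a step that the two limits leave unreadable from compound 1 to compound 2, from compound 1 to compound 3 a step that the two limits leave unreadable from compound 1 to compound 3 and from compound 2 to compound 3 a step that the two limits leave unreadable from compound 2 to compound 3 are all unreadable. Compound 4 `O=C(/C=C\c1cccc(Br)c1)N1N=C(c2ccncc2)OC1c1c[nH]c2ccccc12` differs from compound 2 by 3-bromophenyl in place of 2-hydroxyphenyl on a double-bonded chain carbon bound to a double-bonded chain carbon. The nearest measured step, a step that the two limits leave unreadable from compound 2 to compound 3, bears on it but gives no size. He therefore expects no step beyond the scatter in this assay , a step that the limit leaves unreadable from compound 2 to compound 4, and most likely another limit. Compound 4 is estimated at 40 ug/mL, in the range 20 ug/mL to 100 ug/mL.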

Compound 4, concentration for 50% growth inhibition: > 30 ug/mL
Compound 4: only a limit was reported (the forecaster's own chance of this, stated with the estimate: 85%); the middle value is on the limit's open side.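

In this assay compound 4 gives > 30 ug/mL which is again a limit, so its steps to compound 1, compound 2 and compound 3 cannot be read. The compounds shown leave open whether any of these changes alters growth inhibition at all: the limit of > 30 ug/mL in this assay, at which 4 of the 4 values shown sit.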